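Series notes: methoxy in place of methyl, compound 4

A few compounds are considered here, and "the series" means these few. Any claim that something is new, unique, unknown or untested is made for them only; others in the source may bear on it.

Compound 1 `Cc1ccc2nc(C(=O)Nc3c(F)cc(-c4cccc(F)c4)cc3F)c(C)c(O)c2c1` is the reference of the set; in a functional assay on Hep 3B2 cells (Homo sapiens) for antiproliferative activity, read by MTT assay, with a stated time of 24 h, tested at 100 ug/mL (a higher number here means a stronger effect of the compound at the concentration tested, a lower number a weaker effect), compound 1 gives 68.3%. Compound 2 `Cc1c(C(=O)Nc2c(F)cc(-c3cccc(F)c3)cc2F)nc2ccc(OC(F)(F)F)cc2c1O` carries trifluoromethoxy in place of methyl on an aromatic carbon, and in this assay compound 2 gives 80.3%, a step of a number 12 percentage points higher from compound 1 to compound 2 (beyond the scatter). Compound 3 `Cc1ccc2nc(C(=O)Nc3c(F)cc(-c4cccc(F)c4)cc3F)c(C)c(C(=O)O)c2c1` carries carboxy in place of hydroxy on an aromatic carbon; in this assay compound 3 gives 75.2%, a step of a number 6.9 percentage points higher from compound 1 to compound 3 (within the scatter). Compound 3 stands second of the three numbers, with compound 2 and compound 1 both within the scatter of it, so no order among these three can be read from the values.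

Compound 4 `COc1ccc2nc(C(=O)Nc3c(F)cc(-c4cccc(F)c4)cc3F)c(C)c(C(=O)O)c2c1` differs from compound 3 in one place: methoxy in place of methyl on an aromatic carbon. The closest measured precedent is the replacement of methyl on an aromatic carbon by trifluoromethoxy, which gave a number 12 percentage points higher from compound 1 to compound 2 (beyond the scatter), a modest gain beyond the scatter. The exchange of hydroxy for carboxy, a number 6.9 percentage points higher from compound 1 to compound 3 (within the scatter), concerns a different group and bears little on this change. A small rise, possibly within the scatter, is the expectation; the step is therefore estimated as a number 4.8 percentage points higher from compound 3 to compound 4 (within the scatter) in this assay. Compound 4 is expected to give 80% in this assay, within the range 68% to 90%.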

Compound 4, a percentage reported as inhibition, at one concentration (the size of the read-out at that concentration, not a potency): 28.3%
Beside the measured number, compound 4's estimate is 51.7 percentage points above it; measured number below the stated range.
By their numbers in this assay, from the lowest: compound 4; then compounds 1, 3 and 2 (each within the scatter of the next, the first and the last beyond it).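

On the carboxy-bearing core, methoxy in place of methyl gives a number 46.9 percentage points lower from compound 3 to compound 4 (beyond the scatter) in this assay, the only large step among the compounds shown and the first sign that the change at this aromatic carbon can cost much of the effect at the concentration tested. An oxygen-linked group here therefore does not carry a gain in general: trifluoromethoxy in place of methyl gave a number 12 percentage points higher from compound 1 to compound 2 (beyond the scatter) in the same assay, but on the hydroxy-bearing core, so that step and the new one differ in both the entering group and the group elsewhere on the core. The data shown include no measurement that accounts for the loss.

On these data alone, it remains open whether the loss belongs to methoxy itself or only to methoxy together with the carboxy group, a question that the methoxy counterpart of compound 1 would settle. Also open, as far as these compounds go, is how other groups on this carbon would read in this assay, for instance an amine, or ethoxy as a longer chain on the same oxygen.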